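Trimming the oxadiazole: compound 3 to compound 4

This account rests on a few compounds, and the source may have more. Where it says the series, first, only, none or still open, it means among the compounds named here.

Compound 3 `Cc1nnc(-c2cccnc2-c2ccc(C(=O)Nc3ccc(C(C)(C)C)cc3)cc2)o1` stands at the weak end of this small set. In a functional assay for antagonist activity at transient receptor potential cation channel subfamily V member 1 (Homo sapiens), read by FLIPR (a higher number here means a weaker inhibitor, a lower number a stronger inhibitor), compound 3 gives 387 nM, the highest of the three numbers. Compound 1 `Cc1cccnc1-c1ccc(C(=O)Nc2ccc(C(C)(C)C)cc2)cc1` gives 11 nM in this assay, and compound 2 `CC(C)(C)c1ccc(NC(=O)c2ccc(-c3ncccc3C#N)cc2)cc1` gives 30 nM. Both steps leading to compound 3 are large: a 35-fold higher number from compound 1 to compound 3 (1.55 log units; beyond the scatter) and a 13-fold higher number from compound 2 to compound 3 (1.11 log units; beyond the scatter), while a 2.7-fold higher number from compound 1 to compound 2 (0.44 log units; beyond the scatter) is modest.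

Compound 4 `CC(C)(C)c1ccc(NC(=O)c2ccc(-c3ncccc3-c3nnco3)cc2)cc1` differs from compound 3 by one change: hydrogen in place of methyl on an aromatic carbon. Going by the values given here, none of the measured steps involves removing a methyl from the five-membered ring; all three concern which group sits on the aromatic carbon of the shared core. The measured steps only show that this region of the molecule matters, with the larger groups giving the higher numbers. The change here is small in what it removes, so compound 4 is expected to land near compound 3, with at most a slight lowering of the number: a 1.3-fold lower number from compound 3 to compound 4 (0.11 log units; within the scatter). The estimate for compound 4 is 300 nM, within a range of 100 nM to 900 nM.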

Compound 4, half-maximal inhibitory concentration: 91 nM
Compound 4: middle estimate off by 3.3-fold (0.52 log units), on the high side, and the stated range ends above it.
By their numbers in this assay, from the lowest: compound 1; then compound 2; then compound 4; then compound 3.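

In this assay, the methyl on the oxadiazole matters in its own right: removing it gives a 4.3-fold lower number from compound 3 to compound 4 (0.63 log units; beyond the scatter), so a change of one carbon at this ring position moves the number beyond the scatter. Removing it does not fully close the gap to the simpler groups on the shared core, since replacing the cyano with the 1,3,4-oxadiazol-2-yl group gives a 3.0-fold higher number from compound 2 to compound 4 (0.48 log units; beyond the scatter), and replacing the methyl on the core gives an 8.3-fold higher number from compound 1 to compound 4 (0.92 log units; beyond the scatter). Nothing available explains why either change shifts the number.

The compounds shown leave open how an ethyl group or an amine in place of that methyl would compare with compound 3 and compound 4. They also leave open whether a hydrogen-for-methyl swap would give a similar step on a different five-membered ring.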